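Allyl at the ring nitrogen of an eight-phenyl xanthine

The compounds below may be only part of what the source reports. "The series", "measured", "known", "first", "only" and "open" are said of these compounds alone.

Measured so far:
compound 1, `Cn1c(=O)c2nc(-c3ccc(C(F)(F)F)cc3)[nH]c2n(C)c1=O`, 150 nM
compound 2, `CCCn1c(=O)c2nc(-c3ccc(C(F)(F)F)cc3)[nH]c2n(CCC)c1=O`, 7.5 nM
compound 3, `Cn1c(-c2ccccc2)nc2c1c(=O)[nH]c(=O)n2C`, 3400 nM

The read-out throughout is an assay for binding affinity to adenosine receptor A1 (Rattus norvegicus), read by radioligand binding; on this read-out higher numbers stand for weaker inhibition and lower numbers for stronger inhibition. Compound 3 stands at the top of the three numbers: compound 1 is nearest, with a clearly lower value, and compound 2 is furthest, lower still; both gaps lie beyond the scatter. Compound 1 and compound 2 share the trifluoromethyl-substituted aryl group and differ from each other only in the chains on the ring nitrogens; compound 1 gives 150 nM and compound 2 gives 7.5 nM, so the propyl-bearing compound 2 gives the lower number of the two.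

Compound 4, `C=CCn1c(=O)c2c(nc(-c3ccccc3)n2C)n(C)c1=O`, is not yet measured. Relative to compound 3 it carries allyl in place of hydrogen on an aromatic nitrogen. Within the data shown here, no measured pair isolates exactly this change, so any expectation rests on the direction suggested by the larger chains of compound 2. The step from compound 3 to compound 4 is expected to lower the number, by a 4.9-fold lower number from compound 3 to compound 4 (0.69 log units; beyond the scatter). For compound 4 the estimate in this assay is 700 nM, within a range of 150 nM to 3000 nM.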

Compound 4, inhibition constant: 9000 nM
Beside the measured number, compound 4's estimate is 13-fold (1.11 log units) below it, and the stated range ends below it.
By their numbers in this assay, from the lowest: compound 2; then compound 1; then compound 3; then compound 4.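

In this assay, allyl in place of hydrogen on an aromatic nitrogen gives a 2.6-fold higher number from compound 3 to compound 4 (0.42 log units; beyond the scatter), a modest step beyond the scatter. This is the only pair shown that changes this position alone, and here the added allyl moves the number up rather than down, so the position tolerates allyl at a modest cost on this read-out. No measurement shown accounts for the direction of this step.

On these data alone, whether a longer chain such as butyl, or a chain ending in an amine or a carboxylic acid, would move the number the same way at this nitrogen remains open. As far as these compounds go, it is also open whether allyl here would give a similar step alongside the trifluoromethyl-substituted aryl group of compound 1.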